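The source may report more compounds than this note shows. Statements on the series, on what has been measured and on what is new or still open speak of the compounds shown alone.

Measured so far in a functional assay on A549 cells (Homo sapiens) for cytotoxicity, read by MTT assay, with a stated time of 4 days; on this read-out higher numbers stand for weaker inhibition and lower numbers for stronger inhibition:
Compound 1 `C=C1C[C@]23C[C@@]1(O)CC[C@H]2c1ccc(O)c(C)c1[C@@H]3Cn1cc(-c2ccc(C(F)(F)F)cc2)nn1` gives 10400 nM.
Compound 2 `C=C1C[C@]23C[C@@]1(O)CC[C@H]2c1ccc(O)c(C)c1[C@@H]3Cn1cc(-c2ccc(F)cc2)nn1` gives only a limit of the assay, > 20000 nM.

Compound 2 thus stands at a limit, not at a number, and the step of an at least 1.9-fold higher number from compound 1 to compound 2 (0.28 log units; that floor lies within the scatter) is read against that limit (the limit of > 20000 nM in this assay, at which 1 of the 2 values shown sits). Compound 3 `C=C1C[C@]23C[C@@]1(O)CC[C@H]2c1ccc(O)c(C)c1[C@@H]3Cn1cc(-c2ccc(C)cc2)nn1` differs from compound 2 by methyl in place of fluoro on an aromatic carbon. Going by the values given here, only the step from compound 1 to compound 2 bears on this change, and it itself ends at the limit; the numbers give no basis for a shift beyond the scatter in this assay. Compound 3 is therefore expected near the same limit, estimated at 20000 nM with a range from 8000 nM to 50000 nM, which amounts to an expected a number no higher from compound 2 to compound 3 (the limit leaves the size open).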

Compound 3, half-maximal inhibitory concentration: > 20000 nM
Compound 3: a limit, no number (the forecaster's own chance of this, stated with the estimate: 60%); the middle value sits exactly at the limit.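

In this assay compound 3 gives > 20000 nM, a limit and not a number, so the step between compound 2 and compound 3 cannot be read. Methyl in place of trifluoromethyl gives an at least 1.9-fold higher number from compound 1 to compound 3 (0.28 log units; that floor lies within the scatter), so this change shows no shift beyond the scatter. Methyl now joins fluoro at this position, para to a large group, at the same limit: the limit of > 20000 nM in this assay, at which 2 of the 3 values shown sit.

Still open, as far as these compounds go, is how far the true values of compound 2 and compound 3 lie past that limit. Also open, from the compounds shown here alone, is whether an amine or a carboxylic acid at this position would give a readable number.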